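The source may hold more compounds than are shown below. What is called first, only, known or untested is meant among the compounds shown, and "the series" means these compounds.

Working notes on the series, a functional assay on K562 cells (Homo sapiens) for cytotoxicity, read by MTT assay, with a stated time of 72 h; a higher number here means a weaker inhibitor of growth, a lower number a stronger inhibitor of growth.

Compound 2 `C[Se]/C(=N\C(=O)c1cc(-c2ccccc2)nc2ccccc12)NC(=O)c1cc(-c2ccccc2)nc2ccccc12` gives 30600 nM in this assay. Compound 1 `CS/C(=N\C(=O)c1cc(-c2ccccc2)nc2ccccc12)NC(=O)c1cc(-c2ccccc2)nc2ccccc12` is its sulfur analogue; for compound 1 the read-out is a limit of the assay, not a number, recorded as > 100000 nM. The change between the two, (a group of 2 heavy atoms (1 carbon, 1 sulfur; no ring) in place of a group of 2 heavy atoms (1 carbon, 1 selenium; no ring), on a carbon with a double bond to nitrogen), made the step of an at least 3.2-fold higher number from compound 2 to compound 1 (0.51 log units; beyond the scatter), and the upper end of that step is open, as the value of compound 1 sits at the limit of > 100000 nM in this assay, at which 1 of the 3 values shown sits.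

Compound 3 `C[Se]/C(=N\C(=O)c1cnc2ccccc2c1)NC(=O)c1cnc2ccccc2c1` gives 29900 nM in this assay. The values of compound 3 and compound 2 lie within the scatter of each other, so no order is read between them. How the core of compound 3 differs from the core of compound 2 is not broken down here.

Compound 4 `CS/C(=N\C(=O)c1cnc2ccccc2c1)NC(=O)c1cnc2ccccc2c1` stands to compound 3 as compound 1 stands to compound 2: the change is a group of 2 heavy atoms (1 carbon, 1 sulfur; no ring) in place of a group of 2 heavy atoms (1 carbon, 1 selenium; no ring), on a carbon with a double bond to nitrogen, and the place line is the same word for word as before, so this is the same change on a different core. For compound 4 in this assay the expected step from compound 3 is a 3.3-fold higher number from compound 3 to compound 4 (0.52 log units; beyond the scatter), a weakening of growth inhibition of roughly the earlier size, because the same change produced an at least 3.2-fold higher number from compound 2 to compound 1 (0.51 log units; beyond the scatter) and the value of compound 1 was only a limit. Compound 4 is therefore estimated at 100000 nM, within 45000 nM to 230000 nM, with a real chance that the assay again reports only a limit.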

Compound 4, concentration for total growth inhibition: > 100000 nM
Compound 4 gave a limit, no number; the forecaster's own chance of this, stated with the estimate: 55%; the middle value sits exactly at the limit.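

In this assay, going from the selenium-bearing group to methylsulfanyl, on a carbon with a double bond to nitrogen, gives an at least 3.3-fold higher number from compound 3 to compound 4 (0.52 log units; beyond the scatter), so the weakening of growth inhibition seen on the core of compound 2 recurs on the core of compound 3, in the same direction on both cores: the same change on two cores in this assay, an at least 3.2-fold higher number (0.51 log units; beyond the scatter) from compound 2 to compound 1 and an at least 3.3-fold higher number (0.52 log units; beyond the scatter) from compound 3 to compound 4; the limit leaves it open whether they differ
The two sulfur compounds, compound 1 and compound 4, both sit at a limit of the assay and not at a number: the limit of > 100000 nM in this assay, at which 2 of the 4 values shown sit.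
Going by these compounds, the true size of the step on either core therefore stays unknown, as does any influence of the core on that size, and two cores carry no rule beyond compound 1, compound 2, compound 3 and compound 4.

Open, on these data alone, is how other groups on the same carbon would read in this assay, such as an ethyl group, a longer chain or an amine in place of methylsulfanyl or the selenium-bearing group. Also open, as far as these compounds go, is whether the same change keeps its direction on a core carrying a further group, such as a carboxylic acid or a methoxy group.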